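This account rests on a few compounds, and the source may have more. Where it says the series, first, only, none or still open, it means among the compounds named here.

Working notes on the amidine ether series in an ADME assay on L6 cells (Rattus norvegicus) for cytotoxicity, read by resazurin assay, with a stated time of 72 h; on this read-out higher numbers stand for weaker inhibition and lower numbers for stronger inhibition.

Compound 1 `N=C(N)c1ccc(COc2ccccc2)cc1` is the parent; in this assay compound 1 gives 167000000 nM. Compound 2 `N=C(N)c1ccc(COc2ccc(Cl)cc2)cc1` carries the change chloro in place of hydrogen on an aromatic carbon and in this assay compound 2 gives 20700000 nM, a step of an 8.1-fold lower number from compound 1 to compound 2 (0.91 log units; beyond the scatter). Compound 3 `N=C(N)c1cccc(COc2ccc(C(=N)N)cc2Cl)c1` rests on a different core; the difference between the two cores is not broken down here. In this assay compound 3 gives 13900000 nM, which against compound 2 lies within the scatter and against compound 1 beyond it.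

Compound 4 `N=C(N)c1cccc(COc2c(Cl)cc(C(=N)N)cc2Cl)c1` is not yet measured. It differs from compound 3 by chloro in place of hydrogen on an aromatic carbon. This is the same kind of change as from compound 1 to compound 2, not the same: in compound 2 the chloro enters para to a large group, in compound 4 ortho to a large group, meta to a chloro group and meta to a group of 3 heavy atoms. A step of a 2.8-fold lower number from compound 3 to compound 4 (0.44 log units; beyond the scatter) is expected for compound 4, resting on an 8.1-fold lower number from compound 1 to compound 2 (0.91 log units; beyond the scatter) but taken as smaller since the surroundings differ. Compound 4 is estimated at 5000000 nM, expected between 1500000 nM and 15000000 nM.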

Compound 4, half-maximal inhibitory concentration: 570000 nM
Compound 4: middle estimate off by 8.8-fold (0.94 log units), on the high side; measured number outside the range, below it.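

In this assay, chloro in place of hydrogen on an aromatic carbon again goes with a lower number, here a 24-fold lower number from compound 3 to compound 4 (1.39 log units; beyond the scatter), but the size of the step does not carry over unchanged from one core to the other: the same change on two cores in this assay, an 8.1-fold lower number (0.91 log units; beyond the scatter) from compound 1 to compound 2 and a 24-fold lower number (1.39 log units; beyond the scatter) from compound 3 to compound 4, 3.0-fold (0.48 log units) apart, beyond the scatter of two such steps. The direction is thus shared by the two cores shown, while the step on the core of compound 1 does not serve as a measure of the step on the core of compound 3. Within the data shown here, with only two steps, and with the chloro in compound 4 entering ortho to a large group, meta to a chloro group and meta to a group of 3 heavy atoms, at a different place from that in compound 2, these data do not show whether the core or the place sets the gap.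

The compounds shown leave open whether a fluoro, methyl or methoxy group at the same place would give a step like that of chloro. They also leave open whether the same change on a third core would come closer to the smaller step or the larger one.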